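This account rests on a few compounds, and the source may have more. Where it says the series, first, only, none or still open, it means among the compounds named here.

The study compares three measured compounds and one still to be measured in a functional assay on A549 cells (Homo sapiens) for antiproliferative activity, read by MTT assay, with a stated time of 48 h; a higher number here means a weaker inhibitor, a lower number a stronger inhibitor. Compound 1 `Cc1ccc2[nH]c(-c3cn(-c4ccccc4)nc3-c3ccccc3)nc2c1` gives 3610 nM. Compound 2 `O=C(OCc1ccccc1)c1ccc2[nH]c(-c3cn(-c4ccccc4)nc3-c3ccccc3)nc2c1` differs from compound 1 in one place, (benzyloxycarbonyl in place of methyl on an aromatic carbon); in this assay compound 2 gives 19300 nM, and the change produced a 5.3-fold higher number from compound 1 to compound 2 (0.73 log units; beyond the scatter). Compound 3 `COc1ccc(-c2nn(-c3ccccc3)cc2-c2nc3cc(C)ccc3[nH]2)cc1` gives 5070 nM. It differs from compound 1 by methoxy in place of hydrogen on an aromatic carbon, a difference that gave a 1.4-fold higher number from compound 1 to compound 3 (0.15 log units; within the scatter), so compound 1 and compound 3 cannot be ordered on this evidence.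

Compound 4 `COc1ccc(-c2nn(-c3ccccc3)cc2-c2nc3cc(C(=O)OCc4ccccc4)ccc3[nH]2)cc1` has not yet been measured in this assay. Its relation to compound 3 is benzyloxycarbonyl in place of methyl on an aromatic carbon, the same change that separates compound 1 from compound 2, with the place described in identical words in both cases. Going by the values given here, no measured pair shows whether that change carries over from the core of compound 1 to the core of compound 3; the single earlier step is the only guide. Compound 4 is therefore expected to give about 24000 nM, with a plausible range from 9000 nM to 70000 nM. Among the compounds with values here, the expected step for compound 4 is a 4.7-fold higher number from compound 3 to compound 4 (0.68 log units; beyond the scatter), kept close to the earlier one because a 5.3-fold higher number from compound 1 to compound 2 (0.73 log units; beyond the scatter) is the only measured instance of this change, with a wider range to allow for the untested transfer between cores.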

Compound 4, half-maximal inhibitory concentration: 11900 nM
Compound 4: middle estimate off by 2.0-fold (0.30 log units), on the high side; low and high end bracket the measured number.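

In this assay, benzyloxycarbonyl in place of methyl on the core of compound 3 gives a 2.3-fold higher number from compound 3 to compound 4 (0.37 log units; beyond the scatter), so on both cores the change points toward a weaker inhibitor, and the two steps cannot be told apart in size: the same change on two cores in this assay, a 5.3-fold higher number (0.73 log units; beyond the scatter) from compound 1 to compound 2 and a 2.3-fold higher number (0.37 log units; beyond the scatter) from compound 3 to compound 4, 2.3-fold (0.36 log units) apart, within the scatter of two such steps. Methoxy in place of hydrogen, read on the benzyloxycarbonyl pair, gives a 1.6-fold lower number from compound 2 to compound 4 (0.21 log units; within the scatter), which leaves these two compounds unordered, as with compound 1 and compound 3, and the two methoxy steps also cannot be told apart: the same change on two cores in this assay, a 1.4-fold higher number (0.15 log units; within the scatter) from compound 1 to compound 3 and a 1.6-fold lower number (0.21 log units; within the scatter) from compound 2 to compound 4, 2.3-fold (0.36 log units) apart, within the scatter of two such steps. Going by these compounds alone, this supports carrying the benzyloxycarbonyl change between these two cores as a step in the same direction, but it rests on only two pairs whose cores differ by a single methoxy, so it does not fix the size of the step or show that it would hold on a core that differs more.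

The compounds shown leave open how a carboxylic acid, a methyl ester or a primary amide would read on that aromatic carbon in place of benzyloxycarbonyl. They also leave open whether a chloro or a hydroxy group in place of methoxy would keep the two cores as close as they are here.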